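The source may report more compounds than this note shows. Statements on the series, on what has been measured and on what is new or still open speak of the compounds shown alone.

Measured compounds: compound 1 `Cc1ccc2c(c1C)CN(C(=O)N(C)C)CC2c1ccccc1`, 1200 nM; compound 2 `Cc1ccc2c(c1C)CN(C(=O)N(C)C)CC2c1cccc(Cl)c1`, 3020 nM; compound 3 `CN(C)C(=O)N1Cc2c(Cl)cccc2C(c2cccc(O)c2)C1`, "not determined" (no result reported).

In a functional assay on A2780 cells (Homo sapiens) for antiproliferative activity (a higher number here means a weaker inhibitor, a lower number a stronger inhibitor), compound 1 gives 1200 nM. Compound 2 carries the change chloro in place of hydrogen on an aromatic carbon and gives 3020 nM; this step, a 2.5-fold higher number from compound 1 to compound 2 (0.40 log units; beyond the scatter), is modest. Compound 3 shares the dimethylurea and the saturated ring of compound 1, but the difference between the two cores is not broken down here, and compound 3 has no single number in this assay.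

Compound 4 `CN(C)C(=O)N1Cc2c(ccc(Cl)c2Cl)C(c2cccc(O)c2)C1` is not yet measured. It differs from compound 3 by chloro in place of hydrogen on an aromatic carbon. Among the compounds with values here, this is the same kind of change as the one from compound 1 to compound 2, but its place is not the same: in compound 2 the chloro sits meta to a large group, whereas in compound 4 it sits on a fused or bridged system of two rings, ortho to a chloro group, meta to a fused ring and para to a fused ring. With no value for compound 3 to build on, the expectation rests only on compounds 1 and 2, which lie in a narrow band. Compound 4 is therefore expected at roughly 2000 nM in this assay, with a wide spread from 400 nM to 10000 nM.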

Compound 4, half-maximal inhibitory concentration: 3440 nM
Estimate against measurement, compound 4: 1.7-fold (0.24 log units) below, and the stated range covers the measured number.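

In this assay, within the data shown here, compound 4 gives 3440 nM, but compound 3 has no single number there, so no step from compound 3 to compound 4 can be read. The compounds shown leave open what chloro in place of hydrogen does at this place on the core of compound 3. No evidence shown bears on this result.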